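The source may hold more compounds than are shown below. What is called first, only, known or untested is meant among the compounds shown, and "the series" means these compounds.

In a functional assay on GOTO cells (Homo sapiens) for cytotoxicity, read by MTT assay, with a stated time of 3 days (a lower number here means a stronger inhibitor, a higher number a weaker inhibitor), compound 3 `N#Cc1c(Nc2ccccn2)nc(SCc2nc3ccccc3[nH]2)nc1-c1ccccc1` gives 2.5 nM and holds the lowest number of the three measured compounds. Compound 1 `N#Cc1c(O)nc(SCc2nc3ccccc3[nH]2)nc1-c1ccccc1` gives 7.81 nM and compound 2 `N#Cc1c(Cl)nc(SCc2nc3ccccc3[nH]2)nc1-c1ccccc1` gives 8.62 nM (within the scatter of each other). Compound 4 `N#Cc1c(Nc2nccs2)nc(SCc2nc3ccccc3[nH]2)nc1-c1ccccc1` carries 1,3-thiazol-2-yl in place of pyridin-2-yl on a nitrogen on an aromatic ring. Among the measured compounds shown here, two measured steps bear on this, a 3.1-fold lower number from compound 1 to compound 3 (0.49 log units; beyond the scatter) and a 3.4-fold lower number from compound 2 to compound 3 (0.54 log units; beyond the scatter) and both are modest, yet neither exchanges one such ring for another. In this assay no step beyond the scatter is therefore expected, and no clear direction. The step expected is (a 1.2-fold higher number from compound 3 to compound 4 (0.08 log units; within the scatter)). For compound 4 the estimated value is 3 nM with 1.2 nM to 7.5 nM as the expected range.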

Compound 4, half-maximal inhibitory concentration: 5.1 nM
For compound 4 the middle estimate is 1.7-fold (0.23 log units) below the measured one; the measured number falls inside the stated range.
By their numbers in this assay, from the lowest: compound 3; then compounds 4, 1 and 2 (each within the scatter of the next).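

In this assay the ring on the nitrogen is not freely exchangeable, since 1,3-thiazol-2-yl in place of pyridin-2-yl gives a modest loss (a 2.0-fold higher number from compound 3 to compound 4 (0.31 log units; beyond the scatter)). The (1,3-thiazol-2-yl)amino group cannot be told apart from chloro (a 1.7-fold lower number from compound 2 to compound 4 (0.23 log units; within the scatter)) or hydroxy (a 1.5-fold lower number from compound 1 to compound 4 (0.19 log units; within the scatter)), so among these four compounds only (pyridin-2-yl)amino stands apart at this position. No measured evidence accounts for the difference between the two rings. Open, as far as these compounds go, is whether the ring nitrogen matters at all, which a phenyl group on the same nitrogen would test. A plain methylamino group would show whether any ring is needed there.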